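The compounds below may be only part of what the source reports. "The series", "measured", "known", "first", "only" and "open" are said of these compounds alone.

Among the compounds with values here, compound 1, with the structure `Fc1cc2nc(-c3cccnc3)n(C3CC3)c2cc1F`, is one of two compounds measured in an assay on V79 cells for inhibition of cytochrome P450 11B1, mitochondrial (Homo sapiens), read by HTRF, with a stated time of 1 h; a higher number here means a weaker inhibitor, a lower number a stronger inhibitor. In this assay compound 1 gives 370 nM, and its companion compound 2, with the structure `Fc1ccc2nc(-c3cccnc3)n(C3CC3)c2c1`, gives 401 nM. Within the data shown here, the two numbers sit within the scatter of each other: the single step on record, a 1.1-fold higher number from compound 1 to compound 2 (0.03 log units; within the scatter), shows that taking away one fluoro from the shared core leaves the read-out essentially unchanged.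

Compound 3, with the structure `COc1cncc(-c2nc3cc(F)c(F)cc3n2C2CC2)c1`, has not yet been measured. It differs from compound 1 by methoxy in place of hydrogen on an aromatic carbon; the methoxy carries two heavy atoms and one hydrogen-bond acceptor, and it sits two atoms from the ring nitrogen, meta to a large group.

Among the measured compounds shown here, the only measured step concerns a different position and a different group, so it bears on this change only in showing how little the read-out has moved so far. No step beyond the scatter is therefore expected from compound 1 to compound 3 in this assay, and compound 3 is estimated at 400 nM, within a range of 180 nM to 900 nM, which amounts to an expected step of a 1.1-fold higher number from compound 1 to compound 3 (0.03 log units; within the scatter).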

Compound 3, half-maximal inhibitory concentration: 250 nM
Compound 3: middle estimate off by 1.6-fold (0.20 log units), on the high side; the range from low to high includes it.
By their numbers in this assay, from the lowest: compounds 3, 1 and 2 (each within the scatter of the next).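

Within the data shown here, the earlier compounds spoke only to a fluoro on the shared core, whereas compound 3 is the first to carry a change on the six-membered aromatic ring with 1 nitrogen. The step (a 1.5-fold lower number from compound 1 to compound 3 (0.17 log units; within the scatter)) shows that this position, two atoms from the ring nitrogen and meta to a large group, takes a methoxy in place of hydrogen with the read-out staying within the scatter, so neither of the two single changes on record has moved the number beyond it. No measurement is at hand that could explain why the read-out holds here.

What the compounds shown leave open is whether in this assay an amine, a carboxylic acid or a longer chain such as ethoxy at this same position would give a step beyond the scatter. Also open, going by these compounds, is whether methoxy at this position would leave the read-out as little moved on the core of compound 2, which has hydrogen in place of one fluoro.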